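Trimming the Chloropropyl Urea Tail of Compound 1

The compounds below may be only part of what the source reports. "The series", "measured", "known", "first", "only" and "open" are said of these compounds alone.

Measured compounds and their values:
- compound 1, `Cc1ccccc1OS(=O)(=O)c1ccc(NC(=O)NCCCCl)cc1`: 26000 nM
- compound 2, `CCc1ccccc1OS(=O)(=O)c1ccc(NC(=O)NCCCCl)cc1`: 15000 nM
- compound 3, `O=C(NCCCCl)Nc1ccc(S(=O)(=O)Oc2ccc(O)cc2)cc1`: 50000 nM

In a functional assay on HT-29 cells (Homo sapiens) for cytotoxicity, read by sulforhodamine B assay, with a stated time of 48 h (a lower number here means a stronger inhibitor, a higher number a weaker inhibitor), compound 1 gives 26000 nM. This is the second highest of the three numbers. Its nearest neighbour is compound 2, a step of a 1.7-fold lower number from compound 1 to compound 2 (0.24 log units; within the scatter) that stays within the scatter, and its furthest is compound 3, a step of a 1.9-fold higher number from compound 1 to compound 3 (0.28 log units; within the scatter), also within the scatter. Within the data shown here, the only step beyond the scatter among the three is a 3.3-fold higher number from compound 2 to compound 3 (0.52 log units; beyond the scatter), a modest one.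

The unmeasured compound 4, `CCNC(=O)Nc1ccc(S(=O)(=O)Oc2ccccc2C)cc1`, differs from compound 1 in a different place: hydrogen in place of chloromethyl on a saturated chain carbon, two bonds along the chain from an amide-type nitrogen. Read one bond further out, the chloropropyl becomes ethyl.

All three measured steps change the group on the oxygen, not the chain on the urea nitrogen, so none of them bears on this change. The expectation therefore rests on compound 1 alone and carries a wide range. With nothing shown to anchor the direction, compound 4 is estimated at 50000 nM, with a range from 15000 nM to 160000 nM, meaning an expected step of a 1.9-fold higher number from compound 1 to compound 4 (0.28 log units; within the scatter) in this assay.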

Compound 4, half-maximal inhibitory concentration: 12000 nM
Compound 4: middle estimate off by 4.2-fold (0.62 log units), on the high side, and the stated range ends above it.
By their numbers in this assay, from the lowest: compounds 4, 2, 1 and 3 (each within the scatter of the next, the first and the last beyond it).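

In this assay, the change from 3-chloropropyl to ethyl gives a 2.2-fold lower number from compound 1 to compound 4 (0.34 log units; beyond the scatter). This is the first step shown that touches the chain rather than the group on the oxygen, and it shows that this end of the molecule can shift the read-out, even if only modestly. Removing chloromethyl, and the only chlorine with it, does not weaken the compound here; the number moves towards stronger inhibition, so at least on the core of compound 1, the chlorine-bearing chain end is not required for this level of cytotoxicity. No measurement shown explains why the number moves in this direction.

The compounds shown leave open whether the gain comes from losing the chlorine or from shortening the chain, a question that a plain propyl chain in place of 3-chloropropyl would help separate. As far as these compounds go, it is also open whether the same change would hold with the 2-ethylphenyl or 4-hydroxyphenyl group on the oxygen, and how a longer chain or an amine at the chain end would read.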